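The source may report more compounds than this note shows. Statements on the series, on what has been measured and on what is new or still open speak of the compounds shown alone.

Of the compounds shown here, three have been tested in an assay on HEK293 cells for positive allosteric modulation of metabotropic glutamate receptor 5 (Homo sapiens), read by FLIPR, with a stated time of 1 h; a higher number here means that more compound is needed for the effect, a lower number that less compound is needed. Compound 1 `COc1ccccc1C#Cc1nc2c(s1)C(=O)NCC2` reaches only the assay limit, > 10000 nM. Compound 2 `CN1CCc2nc(C#Cc3cccc(F)c3)sc2C1` likewise gives only a limit, > 10000 nM. Among the compounds with values here, compound 3 `CC1CC1C(=O)N1CCc2nc(C#Cc3ccccc3)sc2C1` is the one compound with an actual number, giving 9.4 nM in this assay, so it stands as the sole reference point. The other two sit at the limit of > 10000 nM in this assay, at which 2 of the 3 values shown sit. Compound 4 `CC1CCCC(C(=O)N2CCc3nc(C#Cc4ccccc4)sc3C2)C1` differs from compound 3 in one place: 3-methylcyclohexyl in place of 2-methylcyclopropyl on a carbonyl carbon. Within the data shown here, no measured pair among the three compounds isolates a change of this kind, so the step can only be guessed. Compound 4 is expected to stay in the same region as compound 3, with a step of a 1.6-fold higher number from compound 3 to compound 4 (0.20 log units; within the scatter) that need not exceed the scatter. The estimate for compound 4 in this assay is 15 nM, with a range from 3 nM to 80 nM.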

Compound 4, half-maximal effective concentration: 100 nM
Compound 4: the middle estimate sits 6.7-fold (0.82 log units) below what was measured; the measured number lies above the stated range.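

Within the data shown here, this is the first step that can be read, and it shows that the group on this carbonyl carbon matters: 3-methylcyclohexyl in place of 2-methylcyclopropyl gives an 11-fold higher number from compound 3 to compound 4 (1.03 log units; beyond the scatter). Even so, compound 4 keeps a measured number in this assay, 100 nM, with the six-membered ring in place. Nothing shown gives a cause for this step. A single step cannot separate ring size from the methyl group. From the compounds shown here alone, how an unsubstituted cyclopentyl ring, a straight butyl chain or a group carrying an amine would read at this position remains open.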